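This account rests on a few compounds, and the source may have more. Where it says the series, first, only, none or still open, it means among the compounds named here.

Compound 1 `N#Cc1cccc(-c2cnc(C(=O)CCc3ccc(-c4ccccc4)cc3)o2)n1` and compound 2 `CSc1cnc(C(=O)CCc2ccc(-c3ccccc3)cc2)o1` share one core and differ in a single group. In an assay for inhibition of Fatty-acid amide hydrolase 1 (Rattus norvegicus) (on this read-out higher numbers stand for weaker inhibition and lower numbers for stronger inhibition), compound 1 gives 2.9 nM, and compound 2 gives 3 nM. The step of a 1.0-fold higher number from compound 1 to compound 2 (0.01 log units; within the scatter) shows that swapping a six-membered aromatic group for methylsulfanyl left the number where it was. Compound 2 thus holds the highest of the two numbers, yet its nearest neighbour, compound 1, sits within the scatter of it, so no order between them can be claimed.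

Compound 3 `O=C(CCc1ccc(-c2ccccc2)cc1)c1ncc(-c2cccnc2)o1` arises from compound 2 by the change (pyridin-3-yl in place of methylsulfanyl on an aromatic carbon). For the measured compounds named here, only one measured step bears on this move, namely a 1.0-fold higher number from compound 1 to compound 2 (0.01 log units; within the scatter), and it was within the scatter, even though it exchanged an aromatic ring for the same methylsulfanyl that now leaves. Compound 3 is therefore expected to show no step beyond the scatter, no change at the digits printed from compound 2 to compound 3 (within the scatter), because compound 1 with an aromatic ring at this place gives 2.9 nM. Compound 3 is estimated at 3 nM, with a range from 1 nM to 9 nM.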

Compound 3, inhibition constant: 1.1 nM
Compound 3: middle estimate off by 2.7-fold (0.44 log units), on the high side; measured number inside the range.
By their numbers in this assay, from the lowest: compound 3; then compounds 1 and 2 (each within the scatter of the next).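

At this place on the five-membered aromatic ring, next to the ring oxygen, the number in this assay does respond to the group carried: pyridin-3-yl in place of methylsulfanyl gives a 2.7-fold lower number from compound 2 to compound 3 (0.44 log units; beyond the scatter) and so moves beyond the scatter, which the earlier exchange did not. The same entering group, in place of 6-cyanopyridin-2-yl, gives a 2.6-fold lower number from compound 1 to compound 3 (0.42 log units; beyond the scatter) and thus stands apart from both earlier groups, so carrying a six-membered aromatic ring here does not by itself set the number. Nothing shown gives an explanation for either step.

The compounds shown leave open whether the gap between the two pyridine groups goes with the nitrile or with the point of attachment of the ring, a question that a plain pyridin-2-yl or a 6-cyanopyridin-3-yl could separate. They also leave open how a phenyl ring, an amine or a carboxylic acid at this place would compare with pyridin-3-yl.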